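The source may hold more compounds than are shown below. What is called first, only, known or untested is meant among the compounds shown, and "the series" means these compounds.

Working notes on the series.

Two compounds carry a number in an ADME assay for permeability, using PAMPA, with a stated time of 4 h; on this read-out higher numbers stand for higher permeability and lower numbers for lower permeability. Compound 1, `Cn1c(COc2cccc(C(=O)O)c2)nc2ccc(Oc3ccc(F)cc3)nc21`, gives 8.6 10^-6 cm/s in this assay. Compound 2, `Cn1c(COc2cccc(C(=O)O)c2)nc2ccc(Oc3ccccn3)cc21`, gives 2.2 10^-6 cm/s in this assay, the lowest of the two numbers shown; the gap from compound 2 to compound 1 lies beyond the scatter of the assay, and nothing more is computed for this pair, so the two values speak only for themselves.

The next compound, compound 3, `Cc1cc(F)cnc1Oc1ccc2nc(COc3cccc(C(=O)O)c3)n(C)c2c1`, is not yet measured in this assay. It differs from compound 2 in one place: 5-fluoro-3-methylpyridin-2-yl in place of pyridin-2-yl on an oxygen on an aromatic ring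

Among the compounds with values here, no step between two measured compounds covers a change of this kind, so the expected size of the step in this assay rests on the two values shown alone. A moderate rise is expected, since compound 1 gives 8.6 10^-6 cm/s while compound 2 gives 2.2 10^-6 cm/s, and the number for compound 3 is not expected to fall below that of compound 2.

For compound 3 the expected step from compound 2 is a 2.0-fold higher number from compound 2 to compound 3 (0.31 log units; beyond the scatter) in this assay. Compound 3 is therefore estimated at 4.5 10^-6 cm/s in this assay, with a range from 2.2 10^-6 cm/s to 9 10^-6 cm/s.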

Compound 3, apparent permeability: 8.3 10^-6 cm/s
Beside the measured number, compound 3's estimate is 1.8-fold (0.27 log units) below it, within the range that was stated.
By their numbers in this assay, from the lowest: compound 2; then compounds 3 and 1 (each within the scatter of the next).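

In this assay, within the data shown here, the change from pyridin-2-yl to 5-fluoro-3-methylpyridin-2-yl on an oxygen on an aromatic ring gives a 3.8-fold higher number from compound 2 to compound 3 (0.58 log units; beyond the scatter) and this is the first step that isolates this position, with the rest of the molecule held constant. The step shows that this position is not silent in this read-out: substitution on the pyridine ring alone moves the number beyond the scatter, while the ring type, the counts of hydrogen-bond donors and acceptors and the absence of net charge stay the same in both groups. No measurement shown here bears on the origin of the step, so the observation stands without an explanation.

Going by these compounds, how much of the step goes with the fluorine and how much with the methyl remains open, as both enter together in this single change and the series shows neither alone on this ring. Also open, on these data alone, is how this assay would respond to a different substituent on the same pyridine ring, such as an amine or a methoxy group, in place of the fluorine or the methyl.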